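Swapping 4-Hydroxyphenyl for 2-Chlorophenyl in Compound 4

The compounds below may be only part of what the source reports. "The series", "measured", "known", "first", "only" and "open" are said of these compounds alone.

Compound 3 `Oc1ccc(N2CCN(C(=S)Nc3ccccc3)CC2)cc1` gives 186000 nM in a toxicity assay on RAW264.7 cells (Mus musculus) for cytotoxicity, read by MTT assay, with a stated time of 24 h (on this read-out lower numbers stand for higher toxicity in this test and higher numbers for lower toxicity in this test), the highest of the two numbers shown. Its nearest neighbour, compound 1 `COc1cc(NC(=S)Nc2cc(OC)c(OC)c(OC)c2)cc(OC)c1OC`, gives 60600 nM, a gap beyond the scatter. Compound 2 `S=C(Nc1ccccc1)N1CCN(c2ncccn2)CC1` gives only a limit of the assay, >= 200000 nM. Within the data shown here, the one measured step, an at least 1.0-fold lower number from compound 2 to compound 3 (0.03 log units; that floor lies within the scatter), is therefore a floor that lies within the scatter (the limit of >= 200000 nM in this assay, at which 1 of the 3 values shown sits). Compound 4 `S=C(Nc1ccccc1)N1CCN(c2ccccc2Cl)CC1` differs from compound 3 by 2-chlorophenyl in place of 4-hydroxyphenyl on an amine nitrogen in a ring. Among the measured compounds shown here, no measured step involves a chlorophenyl group, and the only step at this ring nitrogen was flat, so no change beyond the scatter is expected for compound 4, a 1.3-fold lower number from compound 3 to compound 4 (0.12 log units; within the scatter). Compound 4 is estimated at 140000 nM, within 60000 nM to 250000 nM.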

Compound 4, half-maximal cytotoxic concentration: 30500 nM
The estimate for compound 4 lay 4.6-fold (0.66 log units) above the measured number; the whole stated range lies above it.
By their numbers in this assay, from the lowest: compounds 4 and 1 (each within the scatter of the next); then compound 3. At a limit, above all of these: compound 2.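

At this ring nitrogen the group on the ring can move the result after all: in this assay, 2-chlorophenyl in place of 4-hydroxyphenyl gives a 6.1-fold lower number from compound 3 to compound 4 (0.79 log units; beyond the scatter) toward higher toxicity in this test. The change from pyrimidin-2-yl gives an at least 6.5-fold lower number from compound 2 to compound 4 (0.81 log units; beyond the scatter) in the same direction, but that step is only a floor: the limit of >= 200000 nM in this assay, at which 1 of the 4 values shown sits.

The compounds shown leave open whether the chlorine or the loss of the hydroxyl accounts for the step. A plain phenyl or a methoxyphenyl at this ring nitrogen would help to tell these apart.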